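Replacing the cycloheptyl of compound 1 with phenyl

The source may report more compounds than this note shows. Statements on the series, on what has been measured and on what is new or still open speak of the compounds shown alone.

Measured compounds in an in vitro functional assay on cells for agonist activity at Bombesin receptor subtype-3 (Mus musculus), read by luminescence and calcium flux; on this read-out lower numbers stand for an effect already at smaller amounts and higher numbers for an effect only at larger amounts of compound:
- compound 1, `O=C(O)c1ccccc1-c1ccc(CCc2ncc(CC3CCCCCC3)[nH]2)cc1`: 5.7 nM
- compound 2, `CCCCc1cnc(CCc2ccc(-c3ccccc3C(=O)O)cc2)[nH]1`: 93 nM
- compound 3, `O=C(O)c1ccccc1-c1ccc(CCc2ncc(CCc3ccccc3)[nH]2)cc1`: 174 nM

Among these three, compound 1 stands lowest in this assay; its nearest neighbour is compound 2, reached by a 16-fold higher number from compound 1 to compound 2 (1.21 log units; beyond the scatter), and the furthest is compound 3, reached by a 31-fold higher number from compound 1 to compound 3 (1.48 log units; beyond the scatter). Compound 2 and compound 3 sit close to one another, since a 1.9-fold higher number from compound 2 to compound 3 (0.27 log units; within the scatter) lies within the scatter.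

The unmeasured compound 4, `O=C(O)c1ccccc1-c1ccc(CCc2ncc(Cc3ccccc3)[nH]2)cc1`, differs from compound 1 in one place: phenyl in place of cycloheptyl on a saturated chain carbon bound to an aromatic carbon. The two measured steps that bear on this change both start from compound 1 and both exchange the cycloheptyl for a smaller group on the saturated chain carbon bound to an aromatic carbon. Each of them raised the number by a large margin, as a 16-fold higher number from compound 1 to compound 2 (1.21 log units; beyond the scatter) and a 31-fold higher number from compound 1 to compound 3 (1.48 log units; beyond the scatter) show. The phenyl entering in compound 4 is of a similar size to the propyl and benzyl that entered there in compound 2 and compound 3, so a large rise in this assay is expected again. Compound 4 is therefore estimated at 120 nM, within 30 nM to 500 nM, which means an expected step of a 21-fold higher number from compound 1 to compound 4 (1.32 log units; beyond the scatter).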

Compound 4, half-maximal effective concentration: 11 nM
Estimate against measurement, compound 4: 11-fold (1.04 log units) above; measured number outside the range, below it.
By their numbers in this assay, from the lowest: compounds 1 and 4 (each within the scatter of the next); then compounds 2 and 3 (each within the scatter of the next).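

In this assay the phenyl of compound 4 does about as well as the cycloheptyl on the saturated chain carbon bound to an aromatic carbon (a 1.9-fold higher number from compound 1 to compound 4 (0.29 log units; within the scatter)), so among these compounds a seven-membered non-aromatic ring is not needed there, and an aromatic ring of one carbon fewer can take its place. The large rises seen earlier therefore did not follow from losing the cycloheptyl as such: compound 3 also carries a ring at this place, yet putting phenyl in place of its benzyl brings a large fall (a 16-fold lower number from compound 3 to compound 4 (1.20 log units; beyond the scatter)), and putting phenyl in place of the propyl of compound 2 brings a modest one (an 8.5-fold lower number from compound 2 to compound 4 (0.93 log units; beyond the scatter)). What sets compounds 1 and 4 apart from compounds 2 and 3 is thus the particular group at this place, not simply the presence of a ring, and nothing available explains why these groups differ as they do.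

The compounds shown leave open how a cyclohexyl or a pyridyl would fare at this place. They also leave open whether the phenyl of compound 4 would tolerate a methoxy group, a chlorine or an amine on its ring.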